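The compounds below may be only part of what the source reports. "The series", "measured", "known", "first", "only" and "open" are said of these compounds alone.

Measured so far in an assay on cells for displacement of a labelled ligand from corticotropin-releasing factor receptor 1 (Homo sapiens), with a stated time of 100 min; a lower number here means a stronger inhibitor, a higher number a weaker inhibitor:
compound 1 `C=CCN(CC=C)Cc1c(C(F)(F)F)nc2n(-c3c(C)cc(C)cc3C)c(Cl)cn12` — 13 nM
compound 2 `Cc1cc(C)c(-n2c(Cl)cn3c(CN(C)Cc4ccccc4)c(C(F)(F)F)nc23)c(C)c1` — 160 nM
compound 3 `Cc1cc(C)c(-n2c(Cl)cn3c(CN(C)Cc4ccco4)c(C(F)(F)F)nc23)c(C)c1` — 180 nM

Compound 3 gives the highest of the three numbers; compound 2 lies within the scatter of it a 1.1-fold higher number from compound 2 to compound 3 (0.05 log units; within the scatter), while compound 1 sits well apart a 14-fold higher number from compound 1 to compound 3 (1.14 log units; beyond the scatter).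

Compound 4 `Cc1cc(C)c(-n2c(Cl)cn3c(CN4CCCC4c4ccccc4)c(C(F)(F)F)nc23)c(C)c1` differs from compound 3 by 2-phenylpyrrolidin-1-yl in place of ((furan-2-yl)methyl)(methyl)amino on a saturated chain carbon bound to an aromatic carbon. The bearing steps are those that change the amine substituent: a 12-fold higher number from compound 1 to compound 2 (1.09 log units; beyond the scatter) and a 14-fold higher number from compound 1 to compound 3 (1.14 log units; beyond the scatter), both large, whereas the aryl swap a 1.1-fold higher number from compound 2 to compound 3 (0.05 log units; within the scatter) did nothing beyond the scatter. Within the data shown here, the amine portion therefore drives this assay, but no measured step covers a ring-closed amine, so the direction is uncertain; a modest fall toward compound 1 is expected, a 3.0-fold lower number from compound 3 to compound 4 (0.48 log units; beyond the scatter). Compound 4 is estimated at 60 nM, range 15 nM to 250 nM.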

Compound 4, inhibition constant: > 7000 nM
Compound 4 was reported as a limit; the forecaster's own chance of this, stated with the estimate: 3%; middle value at least 110-fold (2.06 log units) from the limit.
By their numbers in this assay, from the lowest: compound 1; then compounds 2 and 3 (each within the scatter of the next). At a limit, above all of these: compound 4.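

In this assay compound 4 is reported only as a limit: the limit of > 7000 nM in this assay, at which 1 of the 4 values shown sits. The 2-phenylpyrrolidin-1-yl group on this saturated chain carbon gives the largest steps in the series (an at least 38-fold higher number from compound 3 to compound 4 (1.58 log units; beyond the scatter); an at least 43-fold higher number from compound 2 to compound 4 (1.64 log units; beyond the scatter); an at least 530-fold higher number from compound 1 to compound 4 (2.73 log units; beyond the scatter)). The position therefore distinguishes among amines more sharply than compounds 1 to 3 showed, and a phenyl group is tolerated in the benzyl(methyl)amino of compound 2 but not demonstrably in this ring-bound form. Whether the ring itself or its phenyl substituent accounts for the loss remains open. Unsubstituted pyrrolidin-1-yl or piperidin-1-yl at this place would separate the two.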